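A few compounds are considered here, and "the series" means these few. Any claim that something is new, unique, unknown or untested is made for them only; others in the source may bear on it.

Compound 1 `CCCCCCCc1cn(-c2ccc(CNC(=O)[C@H]3NCC[C@@H]3O)cc2)nn1`: 1100 nM in an assay on isolated protein for inhibition of sphingosine kinase 1 (Homo sapiens); on this read-out higher numbers stand for weaker inhibition and lower numbers for stronger inhibition.
Compound 2 `CCCCCCc1nc(-c2ccc(CNC(=O)[C@H]3NCC[C@@H]3O)cc2)no1`: 49 nM.
Compound 3 `CCCCCCCc1nc(-c2ccc([C@H](CC)NC(=O)[C@H]3NCC[C@@H]3O)cc2)no1`: 30 nM.

On these three numbers compound 2 stands second highest. Compound 3 lies closest to it, with a gap that falls within the usual scatter, while compound 1 lies far higher, well beyond the scatter. Compound 4 `CCCCCCCCc1nc(-c2ccc(CNC(=O)[C@H]3NCC[C@@H]3O)cc2)no1` has not yet been measured. It differs from compound 2 in a single place: ethyl in place of hydrogen on a saturated chain carbon, six bonds along the chain from an aromatic carbon. Among the measured compounds shown here, no measured pair shows this change by itself, so the numbers so far offer no direct guide to its effect. Since only the saturated chain grows and everything else is unchanged, the step is expected to be small, a 1.2-fold lower number from compound 2 to compound 4 (0.09 log units; within the scatter), with no direction claimed beyond the scatter. For compound 4 the expected value is 40 nM, most likely between 15 nM and 130 nM.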

Compound 4, half-maximal inhibitory concentration: 86 nM
Estimate against measurement, compound 4: 2.2-fold (0.33 log units) below, within the range that was stated.
By their numbers in this assay, from the lowest: compounds 3, 2 and 4 (each within the scatter of the next, the first and the last beyond it); then compound 1.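

In this assay, ethyl in place of hydrogen on a saturated chain carbon, six bonds along the chain from an aromatic carbon, gives a 1.8-fold higher number from compound 2 to compound 4 (0.24 log units; within the scatter). Among the compounds shown here, this is the first direct reading of this change, and it shows that the chain can grow at this position without a shift that stands clear of the usual scatter. Nothing measured here offers an explanation for this result. One step cannot show a trend with chain length. From the compounds shown here alone, whether a longer chain, or a chain ending in an amine or a carboxylic acid, would keep the number in this range remains open.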